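The compounds below may be only part of what the source reports. "The series", "measured", "known", "first", "only" and "open" are said of these compounds alone.

In a functional assay on PC-3 cells (Homo sapiens) for antiproliferative activity, read by MTT assay, with a stated time of 72 h (on this read-out lower numbers stand for stronger inhibition and higher numbers for weaker inhibition), compound 2 `O=C(NO)c1ccc(OCCOc2ccc3cc2COC/C=C/COCc2cccc(c2)-c2ccnc(n2)N3)cc1` holds the lower of the two numbers at 1600 nM, against compound 1 `O=C(NO)c1ccc(NCCOc2ccc3cc2COC/C=C/COCc2cccc(c2)-c2ccnc(n2)N3)cc1` at 4580 nM. Compound 3 `O=C(NO)c1cccc(NCCOc2ccc3cc2COC/C=C/COCc2cccc(c2)-c2ccnc(n2)N3)c1` departs from compound 2 by (3-(hydroxycarbamoyl)phenyl)amino in place of 4-(hydroxycarbamoyl)phenoxy on a saturated chain carbon, two bonds along the chain from an oxygen on an aromatic ring. Going by the values given here, the one measured step bearing on this is a 2.9-fold lower number from compound 1 to compound 2 (0.46 log units; beyond the scatter), which is modest but beyond the scatter and runs from an amino to an oxy link. Among the compounds with values here, no measured compound yet carries (3-(hydroxycarbamoyl)phenyl)amino itself. A modest rise of similar size is therefore expected in this assay, estimated as a 2.5-fold higher number from compound 2 to compound 3 (0.40 log units; beyond the scatter). For compound 3 the expected value is 4000 nM, with an estimated range of 1500 nM to 11000 nM.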

Compound 3, half-maximal inhibitory concentration: > 100000 nM
Compound 3: no number, only a limit; the forecaster's own chance of this, stated with the estimate: 5%; middle value at least 25-fold (1.39 log units) from the limit.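

Compound 3 stands at a limit of this assay, not at a number: the limit of > 100000 nM in this assay, at which 1 of the 3 values shown sits. With the amino link kept, 3-(hydroxycarbamoyl)phenyl in place of 4-(hydroxycarbamoyl)phenyl on an amine nitrogen gives an at least 21-fold higher number from compound 1 to compound 3 (1.33 log units; beyond the scatter), so the place of the hydroxycarbamoyl on the ring outweighs the earlier link change. Against the oxy-linked compound, the change reads an at least 62-fold higher number from compound 2 to compound 3 (1.79 log units; beyond the scatter), and it combines both changes in one step.

Open, on these data alone, is whether 3-(hydroxycarbamoyl)phenoxy on the same chain falls away likewise. Also open, as far as these compounds go, is how a carboxylic acid in place of the hydroxycarbamoyl, or a longer chain, would read.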